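Swapping Trifluoromethyl for Chloro on the Urea Aryl Ring

This account rests on a few compounds, and the source may have more. Where it says the series, first, only, none or still open, it means among the compounds named here.

In a functional assay on MOLT-4 cells (Homo sapiens) for inhibition, read by sulforhodamine B assay, with a stated time of 48 h, tested at 10 uM (a lower number here means a stronger effect, a higher number a weaker effect of the compound at the concentration tested), compound 1 `COc1cc2cc(Oc3ccc(NC(=O)Nc4ccccc4)cc3)c(C)nc2cc1OC` gives 37.9%, compound 2 `COc1cc2cc(Oc3ccc(NC(=O)Nc4cccc(C(F)(F)F)c4)cc3)c(C)nc2cc1OC` gives 0.81%, and compound 3 `COc1cc2cc(Oc3ccc(NC(=O)Nc4ccc(Cl)c(C(F)(F)F)c4)cc3)c(C)nc2cc1OC` gives -27.9%, the lowest of the three numbers, so compound 3 shows the strongest effect of the set. The two measured steps leading to compound 3 both lowered the number: a number 37.1 percentage points lower from compound 1 to compound 2 (beyond the scatter) and a number 28.7 percentage points lower from compound 2 to compound 3 (beyond the scatter). Compound 4 `COc1cc2cc(Oc3ccc(NC(=O)Nc4ccc(Cl)c(Cl)c4)cc3)c(C)nc2cc1OC` differs from compound 3 by chloro in place of trifluoromethyl on an aromatic carbon. Because both a number 37.1 percentage points lower from compound 1 to compound 2 (beyond the scatter) and a number 28.7 percentage points lower from compound 2 to compound 3 (beyond the scatter) lowered the number, a chloro in place of the trifluoromethyl is expected to keep most of the effect. The expected step is a number 15.9 percentage points higher from compound 3 to compound 4 (beyond the scatter), a modest rise not far beyond the scatter. Compound 4 is therefore estimated at -12%, in a range from -40% to 18%.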

Compound 4, a percentage reported as activity, at one concentration (the size of the read-out at that concentration, not a potency): 3.69%
The estimate for compound 4 lay 15.7 percentage points below the measured number; measured number inside the range.
By their numbers in this assay, from the lowest: compound 3; then compounds 2 and 4 (each within the scatter of the next); then compound 1.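

In this assay, chloro does not fully stand in for trifluoromethyl at this position when a 4-chloro group is present on the ring (a number 31.6 percentage points higher from compound 3 to compound 4 (beyond the scatter)). The 3,4-dichlorophenyl urea still keeps a clear gain over the unsubstituted phenyl (a number 34.2 percentage points lower from compound 1 to compound 4 (beyond the scatter)). Against the 3-(trifluoromethyl)phenyl urea, it cannot be told apart (a number 2.9 percentage points higher from compound 2 to compound 4 (within the scatter)). From the compounds shown here alone, whether a nitrile or an amine at this position would match trifluoromethyl remains open. Nothing measured here explains why trifluoromethyl and chloro differ at this position.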